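Notes: 4-nitrophenyl for 2-methylphenyl on an inactive parent

The compounds below may be only part of what the source reports. "The series", "measured", "known", "first", "only" and "open" are said of these compounds alone.

Measured in a functional assay on HepG2 cells (Homo sapiens) for antiproliferative activity, read by MTT assay; a higher number here means a weaker inhibitor, a lower number a stronger inhibitor:
compound 1 `COc1ccc(NC(=O)Nc2cccc(CNc3ncnc4ccccc34)c2)cc1`: compound 1 gives > 50000 nM, a limit of the assay.
compound 2 `COc1cc2ncnc(NCc3cccc(NC(=O)Nc4ccccc4C)c3)c2cc1OC`: compound 2 gives > 50000 nM, likewise a limit.

Compound 2 stands at the limit, with nothing numerical to place it against, as does everything measured here, see (the limit of > 50000 nM in this assay, at which 2 of the 2 values shown sit).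

Compound 3 `COc1cc2ncnc(NCc3cccc(NC(=O)Nc4ccc([N+](=O)[O-])cc4)c3)c2cc1OC` differs from compound 2 by 4-nitrophenyl in place of 2-methylphenyl on an amide-type nitrogen. Within the data shown here, no measured step covers this change. The step from compound 2 to compound 3 is expected as a step that the limit leaves unreadable from compound 2 to compound 3, none beyond the scatter, in no clear direction. Compound 3 is therefore estimated at 60000 nM, between 20000 nM and 200000 nM, most probably again reported only as a limit.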

Compound 3, half-maximal inhibitory concentration: 18800 nM
Compound 3: middle estimate off by 3.2-fold (0.50 log units), on the high side; the whole stated range lies above it.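

In this assay, among these compounds, 4-nitrophenyl on the amide-type nitrogen gives the first reading that is a number and not a limit, with an at least 2.6-fold lower number from compound 2 to compound 3 (0.42 log units; beyond the scatter). This shows that the group at this position can move the read-out off the limit. The size of the step is only a minimum, since compound 2 is held at a limit: the limit of > 50000 nM in this assay, at which 2 of the 3 values shown sit.

Going by these compounds, whether the step belongs to the nitro group or to the loss of the methyl stays open. On these data alone, how a plain phenyl or a 4-aminophenyl behaves on the same nitrogen is also open.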